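The source may report more compounds than this note shows. Statements on the series, on what has been measured and on what is new or still open speak of the compounds shown alone.

Measured so far in a functional assay on the whole organism (strain Holtzman) with Rattus norvegicus as the target; a higher number here means that more compound is needed for the effect, a lower number that less compound is needed:
Compound 1 `CCn1nc(C)c2c1NC(=O)CN=C2c1ccccc1Cl` gives 5 mg/kg.
Compound 2 `Cc1nn(C(C)C)c2c1C(c1ccccc1Cl)=NCC(=O)N2` gives 20 mg/kg.
Compound 3 `CCCCn1nc(C)c2c1NC(=O)CN=C2c1ccccc1Cl` gives 40 mg/kg.

Compound 3 carries the highest of the three numbers: the step of a 2.0-fold higher number from compound 2 to compound 3 (0.30 log units; within the scatter) lies within the scatter, while an 8.0-fold higher number from compound 1 to compound 3 (0.90 log units; beyond the scatter) lies beyond it. Compound 4 `Cc1nn(-c2ccccc2)c2c1C(c1ccccc1Cl)=NCC(=O)N2` differs from compound 3 by phenyl in place of butyl on an aromatic nitrogen. The steps already seen at this aromatic nitrogen, a 4.0-fold higher number from compound 1 to compound 2 (0.60 log units; beyond the scatter) and an 8.0-fold higher number from compound 1 to compound 3 (0.90 log units; beyond the scatter), went upward as the group grew, although a 2.0-fold higher number from compound 2 to compound 3 (0.30 log units; within the scatter) stayed within the scatter. Among the measured compounds shown here, no measured step puts a ring in place of a chain at this position, so the bearing of those steps is loose. A small rise, or none beyond the scatter, is therefore expected: a 1.5-fold higher number from compound 3 to compound 4 (0.18 log units; within the scatter). Compound 4 is estimated at 60 mg/kg, within 20 mg/kg to 200 mg/kg.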

Compound 4, minimum effective dose: 20 mg/kg
Compound 4: the middle estimate sits 3.0-fold (0.48 log units) above what was measured; the measured number falls inside the stated range.
By their numbers in this assay, from the lowest: compound 1; then compounds 2, 4 and 3 (each within the scatter of the next).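

Phenyl is the first ring on this aromatic nitrogen, and in this assay it gives a 2.0-fold lower number from compound 3 to compound 4 (0.30 log units; within the scatter) and no change at the digits printed from compound 2 to compound 4 (within the scatter), both within the scatter. The ethyl compound still needs less compound, with a 4.0-fold higher number from compound 1 to compound 4 (0.60 log units; beyond the scatter) beyond the scatter, but compound 4 goes against any simple rise with group size, since phenyl has the most heavy atoms here yet does not carry the highest number. The compounds shown leave open how a chain longer than butyl or a chain ending in an amine would read at this nitrogen. On these data alone, a methyl group there is equally open, as is a phenyl ring bearing a chlorine. No evidence is available to explain the result for phenyl.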